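This account rests on a few compounds, and the source may have more. Where it says the series, first, only, none or still open, it means among the compounds named here.

In a functional assay on blood (Homo sapiens) for inhibition (on this read-out higher numbers stand for weaker inhibition and lower numbers for stronger inhibition), compound 1 `Oc1ccc(OCc2ccc3ccccc3n2)cc1C1(c2ccccc2)CC2CCC1C2`, which carries a free hydroxyl on its aromatic ring, gives 580 nM. Compound 2 `CCCCOc1ccc(OCc2ccc3ccccc3n2)cc1C1(c2ccccc2)CC2CCC1C2` has a butyl group in place of that hydroxyl hydrogen. Compound 2 is reported only as a limit, > 3000 nM. Its true value is therefore unknown, and it stands at the weak end of the numbers shown.

Compound 3 `c1ccc(COc2ccc(OCc3ccc4ccccc4n3)cc2C2(c3ccccc3)CC3CCC2C3)cc1` changes the chain on that same oxygen: phenyl in place of propyl on a saturated chain carbon bound to an oxygen on an aromatic ring. Put simply, phenyl takes the place of propyl on a saturated chain carbon bound to an oxygen on an aromatic ring, turning butoxy into benzyloxy.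

Among the compounds with values here, only one measured step bears on this change: butyl replacing hydrogen on the oxygen, an at least 5.1-fold higher number from compound 1 to compound 2 (0.71 log units; beyond the scatter). Compound 3 keeps that oxygen capped, so it resembles compound 2 more closely than compound 1. Within the data shown here, no measured step shows what a phenyl does here, so no clear shift in either direction can be predicted. The expected change is small, within the scatter: a step that the limit leaves unreadable from compound 2 to compound 3. A reading reported only as a limit is quite likely. For compound 3 the estimated value is 3500 nM, with an expected range from 1200 nM to 10000 nM.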

Compound 3, half-maximal inhibitory concentration: > 3000 nM
Compound 3: a limit, no number; the forecaster's own chance of this, stated with the estimate: 65%; the middle value lies beyond the limit too.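

Putting benzyl in place of the hydrogen on this oxygen in this assay gives an at least 5.1-fold higher number from compound 1 to compound 3 (0.71 log units; beyond the scatter). Butyl and benzyl, an open chain and a cap carrying an aromatic ring, therefore both go with clearly weaker inhibition than the free hydroxyl of compound 1, so this loss is no longer tied to one single group on the oxygen. Compound 2 and compound 3 cannot be ranked against each other, and the swap of propyl for phenyl cannot be given a size, because neither compound has a number, only the same limit: the limit of > 3000 nM in this assay, at which 2 of the 3 values shown sit.

As far as these compounds go, how much inhibition each of these two caps actually costs remains unknown, as does whether every group on this oxygen would behave the same way. A methyl on the oxygen, or a chain ending in an amine or a carboxylic acid, would be the kind of group needed to answer that.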